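The compounds below may be only part of what the source reports. "The series", "measured", "known", "first", "only" and "open" are said of these compounds alone.

Of the compounds shown here, three with a shared core have been measured in a functional assay on HCC 2998 cells (Homo sapiens) for cytotoxicity, read by sulforhodamine B assay, with a stated time of 48 h, tested at 10 uM; on this read-out lower numbers stand for a stronger effect and higher numbers for a weaker effect at the one concentration tested. Compound 1 `COc1ccc(-c2cc(/C=C/C(=O)c3ccc(N)cc3)[nH]n2)cc1` gives -90%. Compound 2 `COc1ccc(C(=O)/C=C/c2cc(-c3cc(OC)c(OC)c(OC)c3)n[nH]2)cc1OC` gives -85%, and compound 3 `COc1ccc(C(=O)/C=C/c2cc(-c3cc(OC)c(OC)c(OC)c3)n[nH]2)cc1` gives -83%. Going by the values given here, the only single-place step among them, a number 2 percentage points higher from compound 2 to compound 3 (within the scatter), removes a methoxy group from the aromatic ring next to the carbonyl and leaves the read-out essentially unchanged. Compound 1 sits alongside compound 2 and compound 3: its number differs from each of theirs by less than the usual scatter, so the three cannot be told apart on this read-out.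

Compound 4 `COc1ccc(-c2cc(/C=C/C(=O)c3ccc(N)cc3)[nH]n2)cc1OC` has not yet been measured. It differs from compound 1 in one place: methoxy in place of hydrogen on an aromatic carbon. This is the mirror image of the change seen between compound 2 and compound 3, only on the other aromatic ring of the core and in the opposite direction. Since that step, a number 2 percentage points higher from compound 2 to compound 3 (within the scatter), stayed within the scatter, there is no reason from these data to expect a shift beyond the scatter in this assay in either direction. Compound 4 is therefore expected to give -88%, with a range from -98% to -72%. The expected step, a number 2 percentage points higher from compound 1 to compound 4 (within the scatter), is estimated to stay within the scatter.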

Compound 4, a percentage reported as activity, at one concentration (the size of the read-out at that concentration, not a potency): -75%
Compound 4: middle estimate off by 13 percentage points, on the low side; low and high end bracket the measured number.
By their numbers in this assay, from the lowest: compounds 1, 2, 3 and 4 (each within the scatter of the next, the first and the last beyond it).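

In this assay, methoxy in place of hydrogen on an aromatic carbon, ortho to a methoxy group and meta to a large group, does make a measurable difference here, with a number 15 percentage points higher from compound 1 to compound 4 (beyond the scatter). Compounds 2 and 3 alone could have suggested that this change barely matters, but that holds only for their pair, where a number 2 percentage points higher from compound 2 to compound 3 (within the scatter). The effect of adding or removing a methoxy group therefore does not carry over unchanged from one core to the other in this assay: the same change on two cores in this assay, a number 2 percentage points higher (within the scatter) from compound 2 to compound 3 and a number 15 percentage points lower (beyond the scatter) from compound 4 to compound 1, 17 percentage points apart, beyond the scatter of two such steps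

The cores of the two pairs differ in more than one place, and the methoxy change sits on a different aromatic ring in each, so these compounds cannot show which difference sets the two steps apart. As far as these compounds go, it also remains open whether the step at this position follows from the size of the entering group or from its oxygen, which a fluorine atom, a methyl group or an ethoxy group in the same place could help to separate.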